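Phenyl replacing pyridin-2-yl on the shared core

The source may report more compounds than this note shows. Statements on the series, on what has been measured and on what is new or still open speak of the compounds shown alone.

Measured so far:
compound 1 `CC(C)(O)c1nc(-c2cccc(CNC(=O)c3cnc(-c4ccccn4)nc3)c2)no1` — 7.48 nM
compound 2 `O=C(NCc1ccccc1)c1cnc(-c2ccccn2)nc1` — 7.14 nM
compound 3 `CC(C)(O)c1nc(-c2cccc(CNC(=O)c3ccc(-c4ccccc4)nc3)c2)no1` — 27.7 nM

In an assay on isolated protein for inhibition of Hematopoietic prostaglandin D synthase (Homo sapiens), read by fluorescence polarization (on this read-out lower numbers stand for stronger inhibition and higher numbers for weaker inhibition), compound 1 stands second highest of the three numbers. Its nearest neighbour is compound 2, with a 1.0-fold lower number from compound 1 to compound 2 (0.02 log units; within the scatter) on removing the 5-(1-hydroxy-1-methylethyl)-1,2,4-oxadiazol-3-yl group; compound 3, which differs from compound 1 in two places, shows a plainly higher number. Compound 4 `CC(C)(O)c1nc(-c2cccc(CNC(=O)c3cnc(-c4ccccc4)nc3)c2)no1` carries the change (phenyl in place of pyridin-2-yl on an aromatic carbon). Within the data shown here, no measured step reports this exact change on this core; the step from compound 1 to compound 2 concerns another part of the molecule and offers no guidance. Compound 3, bearing a phenyl in place of a ring with one nitrogen, shows a higher number than compound 1, which suggests a weakening. Compound 4 is therefore expected to show a 3.3-fold higher number from compound 1 to compound 4 (0.52 log units; beyond the scatter). The estimate for compound 4 is 25 nM, ranging from 8 nM to 80 nM.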

Compound 4, half-maximal inhibitory concentration: 7.18 nM
Estimate against measurement, compound 4: 3.5-fold (0.54 log units) above; measured number below the stated range.
By their numbers in this assay, from the lowest: compounds 2, 4 and 1 (each within the scatter of the next); then compound 3.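

In this assay the exchange at this position, on an aromatic carbon between two ring nitrogen atoms, gives a 1.0-fold lower number from compound 1 to compound 4 (0.02 log units; within the scatter) on this core, so the loss of the ring nitrogen of pyridin-2-yl leaves no visible mark. With phenyl also in place, compound 4 reads 7.18 nM and compound 3 reads 27.7 nM here, so phenyl alone does not account for the higher number of compound 3. No measurement shown explains this result. Still open, on these data alone, is how an amine or a carboxylic acid on the phenyl would read, and whether phenyl behaves the same way on compound 2.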